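A Double Bond in the Chain of Compound 3

This account rests on a few compounds, and the source may have more. Where it says the series, first, only, none or still open, it means among the compounds named here.

Three related compounds have been measured so far in a functional assay on P388 cells (Mus musculus) for cytotoxicity (on this read-out higher numbers stand for weaker inhibition and lower numbers for stronger inhibition), and give the numbers that follow. Compound 1 `C[C@@H]1NC(=O)[C@@H](C)NC(=O)[C@@H]2Cc3ccc(O)c(c3)Oc3ccc(cc3)C[C@@H](C(=O)N2C)N(C)C(=O)[C@H](C)NC(=O)[C@H](Cc2ccccc2)N(C)C1=O` gives 42.7 nM there, compound 2 `CCCN1C(=O)[C@@H](C)NC(=O)[C@@H]2Cc3ccc(OC)c(c3)Oc3ccc(cc3)C[C@@H](C(=O)N2C)N(C)C(=O)[C@H](C)NC(=O)[C@H](Cc2ccc(OC)cc2)N(C)C(=O)[C@@H]1C` gives 3.98 nM and compound 3 `CCCCCN1C(=O)[C@@H](C)NC(=O)[C@@H]2Cc3ccc(OC)c(c3)Oc3ccc(cc3)C[C@@H](C(=O)N2C)N(C)C(=O)[C@H](C)NC(=O)[C@H](Cc2ccc(OC)cc2)N(C)C(=O)[C@@H]1C` gives 21.4 nM on the same read-out. Compound 3 thus sits within the usual scatter of compound 1 and clearly apart from compound 2. Compound 4 `CC/C=C/CN1C(=O)[C@@H](C)NC(=O)[C@@H]2Cc3ccc(OC)c(c3)Oc3ccc(cc3)C[C@@H](C(=O)N2C)N(C)C(=O)[C@H](C)NC(=O)[C@H](Cc2ccc(OC)cc2)N(C)C(=O)[C@@H]1C` differs from compound 3 in one place only (but-1-en-1-yl in place of butyl on a saturated chain carbon bound to an amide-type nitrogen in a ring) and, read one bond further out, pentyl becomes pent-2-en-1-yl. Within the data shown here, the only measured step on this chain is a 5.4-fold higher number from compound 2 to compound 3 (0.73 log units; beyond the scatter) and it is modest, though beyond the scatter. Among the measured compounds shown here, that step lengthened the chain, whereas here the chain keeps its length and gains a double bond, a change no measured compound shows. From the compounds shown here alone, no step beyond the scatter is therefore expected, and the direction stays open. The step expected here is a 1.2-fold lower number from compound 3 to compound 4 (0.08 log units; within the scatter) and lies within the scatter. The estimated value for compound 4 is 18 nM with an expected range from 6 nM to 50 nM in repeated measurements.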

Compound 4, half-maximal inhibitory concentration: 12 nM
Compound 4: middle estimate off by 1.5-fold (0.18 log units), on the high side; measured number inside the range.
By their numbers in this assay, from the lowest: compound 2; then compounds 4, 3 and 1 (each within the scatter of the next, the first and the last beyond it).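

In this assay, the double bond that turns pentyl into pent-2-en-1-yl gives a 1.8-fold lower number from compound 3 to compound 4 (0.25 log units; within the scatter), so at this place, with the chain length unchanged, the added double bond has no effect that can be told apart from the scatter. Set against the shorter chain, but-1-en-1-yl in place of ethyl gives a 3.0-fold higher number from compound 2 to compound 4 (0.48 log units; beyond the scatter), which means that among these three compounds the line falls between the shorter chain and the two longer ones, whether saturated or not. Nothing available explains these numbers.

The compounds shown leave open whether a double bond of the opposite geometry, or a triple bond at this place, would read the same. They also leave open how a longer chain such as heptyl, or a chain ending in an amine, would behave here.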